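The source may hold more compounds than are shown below. What is called first, only, known or untested is meant among the compounds shown, and "the series" means these compounds.

In a functional assay on SGC-7901 cells (Homo sapiens) for cytotoxicity, read by MTT assay, with a stated time of 48 h (on this read-out lower numbers stand for stronger inhibition and higher numbers for weaker inhibition), three compounds sharing one core have been measured. Compound 1 `COc1ccc(-c2nnc(SCCn3c([N+](=O)[O-])cnc3C)o2)cc1` gives 10200 nM, compound 2 `Cc1ncc([N+](=O)[O-])n1CCSc1nnc(-c2ccc(N)cc2)o1` gives 31700 nM, and compound 3 `Cc1ncc([N+](=O)[O-])n1CCSc1nnc(-c2ccccc2O)o1` gives 30500 nM. Compound 3 therefore sits level with compound 2, at a 1.0-fold lower number from compound 2 to compound 3 (0.02 log units; within the scatter), and apart from the 4-methoxyphenyl compound, at a 3.0-fold higher number from compound 1 to compound 3 (0.48 log units; beyond the scatter).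

Compound 4 `Cc1ncc([N+](=O)[O-])n1CCSc1nnc(-c2ccc(N)nc2)o1` has 6-aminopyridin-3-yl in place of the 2-hydroxyphenyl of compound 3, on an aromatic carbon of the core: 6-aminopyridin-3-yl in place of 2-hydroxyphenyl on an aromatic carbon. The closest evidence is the exchange of a 4-aminophenyl group for 2-hydroxyphenyl, which gave a 1.0-fold lower number from compound 2 to compound 3 (0.02 log units; within the scatter). The new group carries an amino group, as compound 2 does, and the modest step of a 3.1-fold higher number from compound 1 to compound 2 (0.49 log units; beyond the scatter) shows that compound 2 also stands apart from the methoxy compound. Among the measured compounds shown here, no measured compound has a hetero atom in this aromatic ring, so the uncertainty stays wide.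

No step beyond the scatter is expected in this assay, and the estimated change is a 1.0-fold lower number from compound 3 to compound 4 (0.01 log units; within the scatter). The estimate for compound 4 is 30000 nM, with an expected range from 13000 nM to 65000 nM.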

Compound 4, half-maximal inhibitory concentration: 30900 nM
Estimate against measurement, compound 4: 1.0-fold (0.01 log units) below; low and high end bracket the measured number.
By their numbers in this assay, from the lowest: compound 1; then compounds 3, 4 and 2 (each within the scatter of the next).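

Among the compounds shown here, replacing the carbon-only ring with 6-aminopyridin-3-yl puts a ring hetero atom at this position for the first time, yet in this assay the result stays within the scatter of both neighbours, with a 1.0-fold higher number from compound 3 to compound 4 (0.01 log units; within the scatter) and a 1.0-fold lower number from compound 2 to compound 4 (0.01 log units; within the scatter). The 4-methoxyphenyl group remains the only one set apart, with a 3.0-fold higher number from compound 1 to compound 4 (0.48 log units; beyond the scatter), so these three compounds, with or without the ring nitrogen, sit level while compound 1 alone gives a lower number. Nothing available explains why these different groups give such similar numbers.

Going by these compounds, it remains open whether the lower number of compound 1 depends on the methoxy group itself, which a 4-ethoxyphenyl or 4-chlorophenyl group could help to test. A methoxy group on the pyridine ring would show whether that ring can reach the same level.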